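This account rests on a few compounds, and the source may have more. Where it says the series, first, only, none or still open, it means among the compounds named here.

Of the compounds shown here, three built on one shared core have been tested in a functional assay on the whole organism with Rattus norvegicus as the target; on this read-out lower numbers stand for an effect already at smaller amounts and higher numbers for an effect only at larger amounts of compound. Compound 1 `CNS(=O)(=O)CCn1c(=N)sc2cc(OC(F)(F)F)ccc21` gives 4 mg/kg. Compound 2 `CCSCCn1c(=N)sc2cc(OC(F)(F)F)ccc21` gives 2.2 mg/kg. Compound 3 `C[S+]([O-])CCn1c(=N)sc2cc(OC(F)(F)F)ccc21` gives 1.1 mg/kg. Compound 3 therefore sits at the low end of the three numbers: a 2.0-fold lower number from compound 2 to compound 3 (0.30 log units; within the scatter), a gap that stays within the scatter, whereas a 3.6-fold lower number from compound 1 to compound 3 (0.56 log units; beyond the scatter), which goes beyond it. For comparison, a 1.8-fold lower number from compound 1 to compound 2 (0.26 log units; within the scatter).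

The next compound, compound 4 `CC[S+]([O-])CCn1c(=N)sc2cc(OC(F)(F)F)ccc21`, differs from compound 3 in a single place: methyl in place of hydrogen on a saturated chain carbon bound to a sulfur. Among the measured compounds shown here, none of the measured steps repeats this exact change. The ones that bear on it are the two steps ending at compound 3, both of which alter the group on the saturated chain carbon two bonds along the chain from an aromatic nitrogen, and the swap of one three-heavy-atom group for another between compound 2 and compound 3 stayed within the scatter. Adding one carbon to the chain while the sulfur and oxygen stay in place is thus expected to shift the read-out only modestly, if at all; the step from compound 3 to compound 4 is estimated as a 1.2-fold higher number from compound 3 to compound 4 (0.07 log units; within the scatter). Compound 4 is expected to give about 1.3 mg/kg, with a likely range from 0.5 mg/kg to 3.5 mg/kg.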

Compound 4, dose for half-maximal effect: 1.2 mg/kg
For compound 4 the middle estimate is 1.1-fold (0.03 log units) above the measured one, and the stated range covers the measured number.
By their numbers in this assay, from the lowest: compounds 3, 4, 2 and 1 (each within the scatter of the next, the first and the last beyond it).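

In this assay the step of methyl in place of hydrogen on a saturated chain carbon bound to a sulfur, which reads as methyl to ethyl when cut one bond further out, gives a 1.1-fold higher number from compound 3 to compound 4 (0.04 log units; within the scatter) and stays within the scatter, so this is the first change shown that leaves the sulfur and its oxygen in place, and the extra carbon makes no readable difference. Among the compounds shown here, compound 2 and compound 4 now form the first pair with the same ethyl that differ only by the oxygen on the sulfur, and a 1.8-fold lower number from compound 2 to compound 4 (0.26 log units; within the scatter) also stays within the scatter, while a 3.3-fold lower number from compound 1 to compound 4 (0.52 log units; beyond the scatter) goes beyond it and gives a second compound that stands clearly apart from compound 1. Nothing shown here explains any of these numbers.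

Going by these compounds, only methyl and ethyl have been compared at this position, so a longer chain such as propyl or butyl, a ring such as phenyl, or an amine or a carboxylic acid at the end of the chain remains open. Whether such groups would keep the number this low or shift it beyond the scatter cannot be told from these compounds.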